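A few compounds are considered here, and "the series" means these few. Any claim that something is new, unique, unknown or untested is made for them only; others in the source may bear on it.

Of the compounds shown here, three sharing one core have been measured in a functional assay (aorta) with Rattus norvegicus as the target; on this read-out lower numbers stand for lower potency and higher numbers for higher potency (the scale is a negative logarithm). Compound 1 `CC1(C)C=C(n2ccccc2=O)c2cc(C(=O)c3ccccc3)ccc2O1` gives 6.61 in this assay. Compound 2 `CC1(C)C=C(n2ccccc2=O)c2cc(C=O)ccc2O1` gives 6.91, and the step of a number 0.30 log units higher from compound 1 to compound 2 (within the scatter) is within the scatter. Compound 3 `CC1(C)C=C(n2ccccc2=O)c2cc(O)ccc2O1` gives 5.44, the lowest of the three numbers; the steps of a number 1.17 log units lower from compound 1 to compound 3 (beyond the scatter) and a number 1.47 log units lower from compound 2 to compound 3 (beyond the scatter) both lie beyond the scatter, so compound 3 stands clearly below the other two.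

Compound 4 `CC1(C)C=C(n2ccccc2=O)c2cc(OC(=O)Nc3ccc(F)cc3)ccc2O1` is not yet measured in this assay. It differs from compound 3 in one place: (4-fluorophenyl)carbamoyl in place of hydrogen on an oxygen on an aromatic ring. The two measured steps that bear on this change are those leading to compound 3, where a hydroxy replaced a benzoyl or a formyl and the number fell by a number 1.17 log units lower from compound 1 to compound 3 (beyond the scatter) and a number 1.47 log units lower from compound 2 to compound 3 (beyond the scatter). Going by the values given here, the change to compound 4 moves in the opposite direction, away from the free hydroxy toward a group carrying a carbonyl, so a rise of comparable size is expected rather than no step.

The estimate for compound 4 in this assay is 6.5, with a range from 5.7 to 7.3. This estimate means an expected step of a number 1.06 log units higher from compound 3 to compound 4 (beyond the scatter).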

Compound 4, logarithm of the reciprocal of the active concentration, log(1/C): 5.3
Compound 4: middle estimate off by 1.20 log units, on the high side; the whole stated range lies above it.
By their numbers in this assay, from the lowest: compounds 4 and 3 (each within the scatter of the next); then compounds 1 and 2 (each within the scatter of the next).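

In this assay, (4-fluorophenyl)carbamoyl on the oxygen on the aromatic ring gives a number 0.14 log units lower from compound 3 to compound 4 (within the scatter), so this position accepts a much larger group on that oxygen without any change that can be told from the scatter. It also shows that a carbonyl within the group at this position does not by itself bring the number to that of the benzoyl and formyl compounds: compound 4 gives 5.3, while compound 1 gives 6.61 and compound 2 gives 6.91. Nothing in the data offers an explanation for this result.

On these data alone, it remains open whether a methoxy or acetyl group on this oxygen, or an amine or a carboxylic acid in place of the oxygen, would give numbers that sit with compound 3 and compound 4 or with compound 1 and compound 2. A single carbamoyl compound also leaves the separate contributions of the fluorine, the phenyl ring and the carbamoyl nitrogen unresolved.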